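Branching the amine on the shared core of compound 1

The compounds below may be only part of what the source reports. "The series", "measured", "known", "first", "only" and "open" are said of these compounds alone.

Compound 1 `CCCN(CCC)c1nc(C)nc2c(-c3ccc(Cl)cc3Cl)c(C)nn12` is the point of departure. Among the measured compounds shown here, in an assay on isolated protein for displacement of a labelled ligand from corticotropin-releasing factor receptor 1 (Homo sapiens) (on this read-out higher numbers stand for weaker inhibition and lower numbers for stronger inhibition), compound 1 gives 0.6 nM, the second highest of the three numbers so far. Its nearest neighbour is compound 3 `CCCCN(CC)c1nc(C)nc2c(-c3ccc(Cl)cc3Cl)c(C)nn12`, which gives 0.4 nM, a move of a 1.5-fold lower number from compound 1 to compound 3 (0.18 log units; within the scatter). The furthest is compound 2 `CCCC(CC)Nc1nc(C)nc2c(-c3ccc(Cl)cc3Cl)c(C)nn12`, which gives 1.2 nM. The step from compound 2 to compound 3 is a 3.0-fold lower number from compound 2 to compound 3 (0.48 log units; beyond the scatter), the only one of the three that rises above the scatter.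

Compound 4 `CCCC(CCC)Nc1nc(C)nc2c(-c3ccc(Cl)cc3Cl)c(C)nn12` is not yet measured. Its change relative to compound 1 is (1-propylbutyl)amino in place of dipropylamino on an aromatic carbon. The precedent that bears most directly on it is the step in which dipropylamino also gave way to a secondary amine carrying a branched chain: a 2.0-fold higher number from compound 1 to compound 2 (0.30 log units; within the scatter). That step stayed within the scatter, and the other step from compound 1, to compound 3, did likewise. No measured change on this carbon has moved the number beyond the scatter from compound 1 itself.

Compound 4 is therefore expected to sit close to compound 1, with at most a slight rise in the number, a step of about a 1.7-fold higher number from compound 1 to compound 4 (0.22 log units; within the scatter). The estimate for compound 4 is 1 nM, expected to fall in the range from 0.4 nM to 2.5 nM.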

Compound 4, inhibition constant: 1.6 nM
Compound 4: the middle estimate sits 1.6-fold (0.20 log units) below what was measured, within the range that was stated.
By their numbers in this assay, from the lowest: compounds 3, 1, 2 and 4 (each within the scatter of the next, the first and the last beyond it).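

In this assay, (1-propylbutyl)amino in place of dipropylamino on this aromatic carbon, between two ring nitrogen atoms, gives a 2.7-fold higher number from compound 1 to compound 4 (0.43 log units; beyond the scatter), the first change from compound 1 at this position to pass beyond the scatter. The distance to the butyl(ethyl)amino of compound 3 is also clear, at a 4.0-fold higher number from compound 3 to compound 4 (0.60 log units; beyond the scatter), the widest step among the four compounds. Between the two secondary amines with a branched chain, the added methyl gives only a 1.3-fold higher number from compound 2 to compound 4 (0.12 log units; within the scatter), which stays within the scatter, so extending the branch of compound 2 makes no clear difference, even though compound 4, unlike compound 2, stands beyond the scatter from compound 1.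

Nothing available here accounts for these differences. Still open, going by these compounds, is whether a dialkylamino group of the same size as (1-propylbutyl)amino would stay close to compound 3 or follow compound 4, and whether an amine carrying a ring, such as cyclopropylmethyl(propyl)amino, or ether oxygens, such as bis(2-methoxyethyl)amino, would fit the numbers seen so far on this carbon.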